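This account rests on a few compounds, and the source may have more. Where it says the series, first, only, none or still open, it means among the compounds named here.

Measured in a functional assay on MCF7 cells (Homo sapiens) for inhibition, read by CCK-8 assay, with a stated time of 48 h; on this read-out lower numbers stand for stronger inhibition and higher numbers for weaker inhibition:
- Compound 1 `COc1cc(-c2ccnc3cc(-c4cn(CO)c5ccccc45)nn23)cc(OC)c1OC`: 19 nM
- Compound 2 `COc1cc(-c2ccnc3cc(-c4ccccc4)nn23)cc(OC)c1OC`: 254 nM
- Compound 3 `COc1cc(-c2ccnc3cc(-c4ccc(N(C)C)cc4)nn23)cc(OC)c1OC`: 44 nM

Compound 1 has the lowest number of the three, so it is the strongest inhibitor here. Its value of 19 nM compares with 44 nM for compound 3 and 254 nM for compound 2.

Compound 4 `COc1cc(-c2ccnc3cc(-c4cn(C(=O)OC(C)(C)C)c5ccccc45)nn23)cc(OC)c1OC` keeps the core of compound 1 and changes one group: tert-butoxycarbonyl in place of hydroxymethyl on an aromatic nitrogen. In words, tert-butoxycarbonyl replaces hydroxymethyl on an aromatic nitrogen.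

Among the measured compounds shown here, no step at this nitrogen has been measured. For the measured compounds named here, the only single-place step available is a 5.8-fold lower number from compound 2 to compound 3 (0.76 log units; beyond the scatter), where dimethylamino replaces hydrogen on an aromatic carbon. It is a different change at a different place, so it offers only a rough guide to how far one substitution can move the number in this set.

Starting from the lowest value, a modest rise seems more likely than a further fall, though this is uncertain. The expected change is a 3.2-fold higher number from compound 1 to compound 4 (0.50 log units; beyond the scatter). For compound 4 the estimated value is 60 nM, with an expected range of 15 nM to 250 nM.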

Compound 4, half-maximal inhibitory concentration: 268 nM
For compound 4 the middle estimate is 4.5-fold (0.65 log units) below the measured one, outside the stated range (above it).
By their numbers in this assay, from the lowest: compound 1; then compound 3; then compounds 2 and 4 (each within the scatter of the next).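

Among the compounds shown here, this is the first measured step at the aromatic nitrogen, and it shows that the group there strongly affects the number in this assay: tert-butoxycarbonyl in place of hydroxymethyl gives a 14-fold higher number from compound 1 to compound 4 (1.15 log units; beyond the scatter). The swap alters two things at once, since the entering group has more heavy atoms and no hydrogen-bond donor, whereas hydroxymethyl has one, so this single step cannot separate the two. The data offer no measured explanation for the rise.

From the compounds shown here alone, it remains open how a plain hydrogen, a methyl group or a longer chain ending in an amine on this nitrogen would compare with hydroxymethyl. A small acetyl group would also be informative, as it lies closer in size to hydroxymethyl while, like tert-butoxycarbonyl, carrying a carbonyl.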